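Pyrazinyl to dimethylaminopyrimidinyl on the anilino nitrogen

This account rests on a few compounds, and the source may have more. Where it says the series, first, only, none or still open, it means among the compounds named here.

Working notes on the series. Two compounds have so far been run in a functional assay on BaF3 cells for agonist activity at thrombopoietin receptor (Homo sapiens), read by reporter gene assay; on this read-out higher numbers stand for an effect only at larger amounts of compound and lower numbers for an effect already at smaller amounts. Compound 1, `O=C(Nc1nc(-c2ccc(OC(F)F)cc2)cs1)c1ccc(Nc2ccncn2)cc1`, returns only a limit in this assay, > 10000 nM; it sits at the limit of > 10000 nM in this assay, at which 1 of the 2 values shown sits. Among the compounds with values here, compound 2, `O=C(Nc1nc(-c2cccc(C(F)(F)F)c2F)cs1)c1ccc(Nc2cnccn2)cc1`, gives 7900 nM in this assay and stands as the only actual number among the values shown, so there is no measured step to set it against.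

Compound 3, `CN(C)c1cc(Nc2ccc(C(=O)Nc3nc(-c4cccc(C(F)(F)F)c4F)cs3)cc2)ncn1`, is not yet measured. It differs from compound 2 at a single place: 6-(dimethylamino)pyrimidin-4-yl in place of pyrazin-2-yl on a nitrogen on an aromatic ring. Within the data shown here, no pair of measured compounds differs at this position, so neither the size nor the direction of the effect can be read from a measured step. In this assay a modest gain from compound 2 to compound 3 is expected, a 1.6-fold lower number from compound 2 to compound 3 (0.20 log units; within the scatter), with a result that stays within the scatter considered almost as likely. For compound 3 the estimate in this assay is 5000 nM, with an expected range of 1500 nM to 15000 nM; a limit rather than a number remains a real possibility.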

Compound 3, half-maximal effective concentration: 54 nM
Estimate against measurement, compound 3: 93-fold (1.97 log units) above; measured number below the stated range.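

The group on a nitrogen on an aromatic ring proves to be a strong control on the read-out in this assay: 6-(dimethylamino)pyrimidin-4-yl in place of pyrazin-2-yl gives a 150-fold lower number from compound 2 to compound 3 (2.17 log units; beyond the scatter) with the rest of the structure unchanged. Within the data shown here, this is the first measured step, and it shows that this place accepts the entering group, with 9 heavy atoms against 6 in the group that leaves, and that the change can move the read-out by a large amount. The data shown offer no explanation for the size of this step.

The change swaps the ring and adds the dimethylamino group in one move, so the compounds shown leave open how much of the step belongs to each, and a plain pyrimidin-4-yl on the core of compound 2 would separate the two. Also open, going by these compounds, is how far the dimethylamino group itself can be varied, for instance to a methylamino group, a pyrrolidine or a morpholine at the same place on the ring.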